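Pyridin-2-yl in Place of Phenyl on a Shared Core

This account rests on a few compounds, and the source may have more. Where it says the series, first, only, none or still open, it means among the compounds named here.

Measured so far in an assay on isolated protein for inhibition of RAC-beta serine/threonine-protein kinase (Homo sapiens), read by mobility shift assay, tested at 30 uM; a higher number here means more inhibition at the concentration tested (going by the name of the read-out), a lower number less inhibition:
compound 1 `Nc1n[nH]c2cc(-c3ccccn3)[nH]c(=O)c12` gives 8%;
compound 2 `Cc1cc2c(c(N)nn2C)c(=O)[nH]1` gives 4%;
compound 3 `Cn1nc(N)c2c(=O)[nH]c(-c3ccccc3)cc21` gives 4%.

Compound 3 stands level with compound 2 at the digits printed, the two together being the lowest of the three numbers, and its gap to compound 1 is within the scatter. Among the compounds with values here, the one measured step, no change at the digits printed from compound 2 to compound 3 (within the scatter), shows that exchanging methyl for phenyl left the read-out unchanged. Compound 4 `Cn1nc(N)c2c(=O)[nH]c(-c3ccccn3)cc21` carries the change (pyridin-2-yl in place of phenyl on an aromatic carbon). Within the data shown here, no measured step covers this exchange, and compound 1 differs from compound 4 in more than one place, so only its value can be set beside the others. The expected step of a number 1 percentage points higher from compound 3 to compound 4 (within the scatter) is therefore none beyond the scatter. Compound 4 is estimated at 5%, within 0% to 15%.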

Compound 4, a percentage reported as inhibition, at one concentration (the size of the read-out at that concentration, not a potency): 10%
Beside the measured number, compound 4's estimate is 5 percentage points below it; low and high end bracket the measured number.
By their numbers in this assay, from the lowest: compounds 2, 3, 1 and 4 (each within the scatter of the next).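

In this assay pyridin-2-yl in place of phenyl on this aromatic carbon gives a number 6 percentage points higher from compound 3 to compound 4 (within the scatter) and in place of methyl gives a number 6 percentage points higher from compound 2 to compound 4 (within the scatter) so adding a ring nitrogen at this position moves the read-out by nothing beyond the scatter. Methyl in place of hydrogen on the aromatic nitrogen gives a number 2 percentage points higher from compound 1 to compound 4 (within the scatter) here, so that site also shows nothing beyond the scatter. No supporting evidence is available to explain these small differences.

As far as these compounds go, whether an amine or a carboxylic acid on this aromatic carbon would lift the read-out beyond the scatter remains open.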